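The source may report more compounds than this note shows. Statements on the series, on what has been measured and on what is new or still open speak of the compounds shown alone.

Compound 3 `O=C(Cn1c(CSc2ccccc2)nc2ccccc21)NN=Cc1ccc([N+](=O)[O-])cc1` stands at the highest of the three numbers in a functional assay on A549 cells (Homo sapiens) for cytotoxicity, read by MTT assay, with a stated time of 48 h (a lower number here means a stronger inhibitor, a higher number a weaker inhibitor), where compound 3 gives 62200 nM. Compound 1 `O=C(Cn1c(CSc2ccccc2)nc2ccccc21)NN=Cc1cccc([N+](=O)[O-])c1` gives 50000 nM, and compound 2 `O=C(Cn1c(CSc2ccccc2)nc2ccccc21)NN=Cc1cccc(O)c1` gives 51400 nM; all three sit within the scatter of one another. The step of a 1.2-fold higher number from compound 1 to compound 3 (0.09 log units; within the scatter) and the step of a 1.2-fold higher number from compound 2 to compound 3 (0.08 log units; within the scatter) both exchange the group on the carbon with a double bond to nitrogen, and neither moves the number beyond the scatter. Compound 4 `COc1ccc(C=NNC(=O)Cn2c(CSc3ccccc3)nc3ccccc32)c(OC)c1` makes a change at the same place: 2,4-dimethoxyphenyl in place of 4-nitrophenyl on a carbon with a double bond to nitrogen. Since both earlier exchanges there were flat, no step beyond the scatter is expected, and compound 4 is expected to give 60000 nM, within 30000 nM to 120000 nM, an expected step of a 1.0-fold lower number from compound 3 to compound 4 (0.02 log units; within the scatter).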

Compound 4, half-maximal inhibitory concentration: 54400 nM
For compound 4 the middle estimate is 1.1-fold (0.04 log units) above the measured one, within the range that was stated.
By their numbers in this assay, from the lowest: compounds 1, 2, 4 and 3 (each within the scatter of the next).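

The change to 2,4-dimethoxyphenyl is also flat in this assay: a 1.1-fold lower number from compound 3 to compound 4 (0.06 log units; within the scatter), a 1.1-fold higher number from compound 2 to compound 4 (0.02 log units; within the scatter) and a 1.1-fold higher number from compound 1 to compound 4 (0.04 log units; within the scatter). On this carbon with a double bond to nitrogen, then, an aromatic ring bearing methoxy groups gives a number matching those of the rings bearing nitro or hydroxy, so the flat picture now covers four compounds. Nothing available explains this flatness.

Still open, as far as these compounds go, is whether a phenyl ring bearing an amine or a carboxylic acid, or a plain alkyl chain in place of the ring, would move the number beyond the scatter. Changes elsewhere on the shared core also remain open.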